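Swapping a nitro-bearing ring for a dichlorophenyl ring

This account rests on a few compounds, and the source may have more. Where it says the series, first, only, none or still open, it means among the compounds named here.

Of the compounds shown here, two sharing one core have been measured. Compound 1 `O=C(/C=C/c1ccc(Cl)c([N+](=O)[O-])c1)/C=C/c1ccccc1Oc1ncnc2ccc(Cl)cc12` gives 62.5% in a functional assay on PC-3 cells (Homo sapiens) for inhibition, read by MTT assay, with a stated time of 72 h, tested at 10 uM; on this read-out higher numbers stand for more inhibition of growth at the one concentration tested and lower numbers for less inhibition of growth. Compound 2 `O=C(/C=C/c1cc([N+](=O)[O-])ccc1Cl)/C=C/c1ccccc1Oc1ncnc2ccc(Cl)cc12` gives 86.9% in this assay, the higher of the two numbers, and the step of a number 24.4 percentage points higher from compound 1 to compound 2 (beyond the scatter) lies beyond the scatter. Compound 3 `O=C(/C=C/c1ccc(Cl)c(Cl)c1)/C=C/c1ccccc1Oc1ncnc2ccc(Cl)cc12` has not yet been measured; it differs from compound 2 by 3,4-dichlorophenyl in place of 2-chloro-5-nitrophenyl on a double-bonded chain carbon bound to a double-bonded chain carbon. Within the data shown here, the only measured step, from compound 1 to compound 2, rearranged a chlorine and a nitro group on the same ring and moved the number modestly; no measured step removes the nitro group altogether, so the bearing of that step on compound 3 is indirect. The expected step of a number 16.9 percentage points lower from compound 2 to compound 3 (beyond the scatter) in this assay is therefore a modest move downward, with wide uncertainty. Compound 3 is estimated at 70% in this assay, within a range from 45% to 92%.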

Compound 3, percent growth inhibition at one concentration: 42.2%
Compound 3: the middle estimate sits 27.8 percentage points above what was measured; measured number outside the range, below it.
By their numbers in this assay, from the lowest: compound 3; then compound 1; then compound 2.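

Chloro in place of nitro on an aromatic carbon gives a number 20.3 percentage points lower from compound 1 to compound 3 (beyond the scatter) in this assay; this is the first measured change that removes the nitro group and leaves the rest of the molecule untouched. The wider change, 3,4-dichlorophenyl in place of 2-chloro-5-nitrophenyl, gives a number 44.7 percentage points lower from compound 2 to compound 3 (beyond the scatter), a large step at this position on the double-bonded chain carbon. Among these three compounds, both that carry a nitro group give higher numbers than compound 3, and none goes against this.

Nothing given here explains why the numbers fall in this order. On these data alone, it remains open whether an amine or a methoxy group on this ring, in place of the nitro group, would keep growth inhibition near that of compound 2 at 86.9%.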